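Swapping an amide arm for a plain alkyl chain

The source may hold more compounds than are shown below. What is called first, only, known or untested is meant among the compounds shown, and "the series" means these compounds.

Of the compounds shown here, two sharing a fused bicyclic core have been tested in a functional assay on PANC-1 cells (Homo sapiens) for antiproliferative activity, read by sulforhodamine B assay, with a stated time of 48 h; a higher number here means a weaker inhibitor of growth, a lower number a stronger inhibitor of growth. Compound 1 `CCc1nc2nc(C(F)(F)F)ccc2c(=O)n1Cc1cn(CCC(F)(F)C(F)(F)C(F)(F)C(F)(F)C(F)(F)C(F)(F)F)nn1` gives 730 nM. Compound 2 `O=C(Cn1cc(COc2nc(-c3ccccc3)nc3nc(C(F)(F)F)ccc23)nn1)Nc1ccccc1` gives 4500 nM, the higher of the two numbers, and its gap to compound 1 is beyond the usual scatter. Compound 3 `CCCCCCCCCCn1cc(COc2nc(-c3ccccc3)nc3nc(C(F)(F)F)ccc23)nn1` has not yet been measured. It differs from compound 2 in one place: nonyl in place of phenylcarbamoyl on a saturated chain carbon bound to an aromatic nitrogen, so that the side arm becomes a long saturated chain instead of an amide bearing a benzene ring. Within the data shown here, no measured pair shows this exact change. Because compound 1, which also carries an extended chain on that nitrogen, gives 730 nM, a moderate drop in number is expected for compound 3, of the size a 2.5-fold lower number from compound 2 to compound 3 (0.40 log units; beyond the scatter). The estimate for compound 3 is therefore 1800 nM, with a range from 600 nM to 5000 nM.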

Compound 3, concentration for 50% growth inhibition: 490 nM
Beside the measured number, compound 3's estimate is 3.7-fold (0.57 log units) above it; measured number outside the range, below it.
By their numbers in this assay, from the lowest: compounds 3 and 1 (each within the scatter of the next); then compound 2.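

At this position, on a saturated chain carbon bound to an aromatic nitrogen, nonyl in place of phenylcarbamoyl gives a 9.2-fold lower number from compound 2 to compound 3 (0.96 log units; beyond the scatter) in this assay. This is the first pair shown that differs in one place, and it shows that a compound of this series can inhibit growth more strongly with neither the benzene ring nor the amide in its side arm, carrying a plain saturated chain with no hydrogen-bond donor or acceptor instead. No measurement shown here explains this drop in the number.

The step removes the amide and the benzene ring together, so the compounds shown leave open which of the two accounts for it. Also open, on these data alone, is whether a shorter chain such as butyl, a longer chain such as dodecyl, or a nonyl chain ending in an amine or a carboxylic acid would keep the number this low.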